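Aryl amide exchange on the shared core

The source may hold more compounds than are shown below. What is called first, only, known or untested is meant among the compounds shown, and "the series" means these compounds.

The series shares the core seen in compound 1 `C/C=C/C(=O)Nc1c(C(O)(C(F)(F)F)C(F)(F)F)ccc2ccccc12`, an amide whose carbonyl carbon carries the variable group. In an assay on LtK cells with ATP-sensitive inward rectifier potassium channel 11 (Homo sapiens) as the target (a higher number here means that more compound is needed for the effect, a lower number that less compound is needed), compound 1 gives 72 nM. Going by the values given here, compound 2 `O=C(Nc1c(C(O)(C(F)(F)F)C(F)(F)F)ccc2ccccc12)c1ccccc1Cl` carries a 2-chlorophenyl on that carbonyl carbon, and in this assay compound 2 gives 2040 nM, the higher of the two numbers so far. Among the compounds with values here, the only measured step, a 28-fold higher number from compound 1 to compound 2 (1.45 log units; beyond the scatter), is large.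

Within the data shown here, compound 3 `COc1cccc(C(=O)Nc2c(C(O)(C(F)(F)F)C(F)(F)F)ccc3ccccc23)c1` is the next member. 3-methoxyphenyl in place of 2-chlorophenyl on a carbonyl carbon Both the group that leaves and the group that enters are six-membered aromatic rings of carbon only, on the same carbonyl carbon, so the single measured step does not test this kind of exchange: it shows only that an aromatic ring in place of prop-1-en-1-yl raised the number sharply. Among the measured compounds shown here, no measured step bears directly on one aromatic ring replacing another. The expected step is a 1.4-fold lower number from compound 2 to compound 3 (0.13 log units; within the scatter), which is not expected to exceed the scatter, with a wide range in the absence of a guide. The estimate for compound 3 in this assay is 1500 nM, between 400 nM and 6000 nM.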

Compound 3, half-maximal effective concentration: 185 nM
Compound 3: middle estimate off by 8.1-fold (0.91 log units), on the high side; measured number below the stated range.
By their numbers in this assay, from the lowest: compound 1; then compound 3; then compound 2.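

In this assay, going by these compounds alone, the first exchange of one aromatic ring for another on this carbonyl carbon is itself a large step (an 11-fold lower number from compound 2 to compound 3 (1.04 log units; beyond the scatter)), so an aromatic ring here is not tied to a number as high as that of compound 2: the outcome depends on which ring is attached. The other new step is only modest (a 2.6-fold higher number from compound 1 to compound 3 (0.41 log units; beyond the scatter)), and it is beyond the scatter, so 3-methoxyphenyl recovers much of the loss seen with 2-chlorophenyl (a 28-fold higher number from compound 1 to compound 2 (1.45 log units; beyond the scatter)) while the prop-1-en-1-yl of compound 1 keeps the lowest number of the three. Nothing available on these compounds accounts for the difference between the two rings.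

The two rings differ both in the group they carry and in where it is carried, so the step cannot be assigned to either, and a 3-chlorophenyl or a 2-methoxyphenyl on the same carbonyl carbon would separate the two. Going by these compounds, it also remains open whether an amine or a carboxylic acid on the ring, or a longer chain in place of prop-1-en-1-yl, would give a number lower than that of compound 1.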